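Adding a Methyl Group to Compound 1

This account rests on a few compounds, and the source may have more. Where it says the series, first, only, none or still open, it means among the compounds named here.

Compound 1 `O=C1C(O)=C(C(c2ccc([N+](=O)[O-])cc2)c2c[nH]c3ccccc23)C(=O)c2ccccc21` belongs to a set of three compounds that share one core and differ only in the group bound to a saturated chain carbon. In a functional assay on HeLa cells (Homo sapiens) for cytotoxicity, read by MTT assay, with a stated time of 48 h (on this read-out lower numbers stand for stronger inhibition and higher numbers for weaker inhibition), compound 1 gives 14800 nM. Compound 2 `O=C1C(O)=C(C(c2cccc([N+](=O)[O-])c2)c2c[nH]c3ccccc23)C(=O)c2ccccc21` gives 24900 nM in this assay, and compound 3 `O=C1C(O)=C(C(c2cccs2)c2c[nH]c3ccccc23)C(=O)c2ccccc21` gives 12400 nM. Compound 1 stands second highest of the three numbers: its step to compound 3 is a 1.2-fold lower number from compound 1 to compound 3 (0.08 log units; within the scatter), and its step to compound 2 is a 1.7-fold higher number from compound 1 to compound 2 (0.23 log units; within the scatter); the remaining step is a 2.0-fold lower number from compound 2 to compound 3 (0.30 log units; within the scatter). Compound 4 `Cc1[nH]c2ccccc2c1C(C1=C(O)C(=O)c2ccccc2C1=O)c1ccc([N+](=O)[O-])cc1` differs from compound 1 by methyl in place of hydrogen on an aromatic carbon. Going by the values given here, none of the measured steps touches this place; each of them exchanges the group on the saturated chain carbon, and all three leave the numbers within the scatter of one another. What they offer is only that this read-out has so far been insensitive to changes around the core, with no exception among compounds 1, 2 and 3. Compound 4 is therefore expected to show no step beyond the scatter in this assay, that is no change at the digits printed from compound 1 to compound 4 (within the scatter). The estimate for compound 4 is 14800 nM, with a range from 7000 nM to 30000 nM.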

Compound 4, half-maximal inhibitory concentration: 4570 nM
The estimate for compound 4 lay 3.2-fold (0.51 log units) above the measured number; the whole stated range lies above it.
By their numbers in this assay, from the lowest: compound 4; then compounds 3, 1 and 2 (each within the scatter of the next).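

In this assay, methyl in place of hydrogen on an aromatic carbon of the five-membered aromatic ring, next to the ring nitrogen and next to the ring atom that bears a large group, gives a 3.2-fold lower number from compound 1 to compound 4 (0.51 log units; beyond the scatter) as a modest step. Going by these compounds alone, this is the only step in the set that lies beyond the scatter, so this read-out is not insensitive to every change around the shared core: the change from 1H-indol-3-yl to 2-methyl-1H-indol-3-yl moves the number in a way that the exchanges on the saturated chain carbon among compounds 1, 2 and 3 did not. No measurement is available to account for this step.

The compounds shown leave open whether the effect at this place is particular to methyl or extends to a longer chain such as ethyl, to an amine or to a chlorine atom. They also leave open whether the same methyl would give a comparable step with 3-nitrophenyl or thiophen-2-yl on the saturated chain carbon, as in compound 2 and compound 3.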